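This account rests on a few compounds, and the source may have more. Where it says the series, first, only, none or still open, it means among the compounds named here.

The series shares one core, seen in compound 1 `CCOC(=O)CCCCCOc1cccc(CN(C(=O)c2ccc(-c3ccc4ccccc4c3)cc2)C(C)C)c1`, compound 2 `CCOC(=O)CCCCCOc1cccc(CN(C(=O)c2ccc(-c3cnc(OC)nc3OC)cc2)C(C)C)c1` and compound 3 `CCOC(=O)CCCCCOc1cccc(CN(C(=O)c2ccc(-c3cccc(C(C)=O)c3)cc2)C(C)C)c1`, and the three differ only in the group on an aromatic carbon. In an ADME assay on Raji cells (Homo sapiens) for cytotoxicity, read by CellTiter-Glo and resazurin assay, with a stated time of 72 h (a higher number here means that more compound is needed for the effect, a lower number that less compound is needed), compound 1 gives a value that is a limit of the assay, > 26000 nM. Compound 2 likewise gives only a limit in this assay, > 26000 nM. Compound 3 also gives only a limit in this assay, > 26000 nM, so where it stands is known as a limit alone, and the same is true of the two other compounds. The steps among them are a step that the two limits leave unreadable from compound 1 to compound 2, a step that the two limits leave unreadable from compound 1 to compound 3 and a step that the two limits leave unreadable from compound 2 to compound 3; none of them can be sized because of the limit of > 26000 nM in this assay, at which 3 of the 3 values shown sit.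

Compound 4 `CCOC(=O)CCCCCOc1cccc(CN(C(=O)c2ccc(-c3ccc4[nH]ccc4c3)cc2)C(C)C)c1` has not yet been measured. It differs from compound 3 in this way: 1H-indol-5-yl in place of 3-acetylphenyl on an aromatic carbon. The measured steps that bear on this exchange are the three just named, and all of them are unreadable, so they give neither a size nor a direction. With every measured compound sitting at the limit, the step from compound 3 to compound 4 is expected to be a step that the limit leaves unreadable from compound 3 to compound 4, no readable change. Compound 4 is therefore estimated to give 30000 nM in this assay, within 13000 nM to 70000 nM, most probably once more reported only as a limit.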

Compound 4, half-maximal effective concentration: > 26000 nM
Compound 4 gave a limit, no number; the forecaster's own chance of this, stated with the estimate: 80%; the middle value does not contradict the limit.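

In this assay compound 4 also gives only a limit, > 26000 nM, so none of its steps to compound 1, compound 2 or compound 3 can be read, because all of them end at the same limit: the limit of > 26000 nM in this assay, at which 4 of the 4 values shown sit.

The compounds shown leave open whether the group exchanged on the aromatic carbon changes the value in this assay at all, and in which direction.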